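Swapping bromo for chloro on a benzothiazole: expected tolerability

A few compounds are considered here, and "the series" means these few. Any claim that something is new, unique, unknown or untested is made for them only; others in the source may bear on it.

Compound 1 `NNc1nc2ccc(F)cc2s1` gives 13.8 ug/mL in an ADME assay on MT4 cells (Homo sapiens) for cytotoxicity, read by MTT assay, with a stated time of 5 days; a lower number here means that less compound is tolerated, a higher number that more compound is tolerated.
Compound 2 `Cc1ccc2nc(NN)sc2c1` gives 4.52 ug/mL in this assay.
Compound 3 `O=[N+]([O-])c1ccc(-c2nnc(-c3cccnc3)n2Nc2nc3ccc(Br)cc3s2)cc1` gives 13.2 ug/mL in this assay.

Compound 3 sits close to compound 1, within the usual scatter, while the value of compound 2 lies well beneath both. The next compound, compound 4 `O=[N+]([O-])c1ccc(-c2nnc(-c3cccnc3)n2Nc2nc3ccc(Cl)cc3s2)cc1`, carries the change (chloro in place of bromo on an aromatic carbon). Going by the values given here, no measured step involves a swap of one halogen for another; the only measured step, a 3.1-fold lower number from compound 1 to compound 2 (0.48 log units; beyond the scatter), concerns methyl replacing fluoro, so it offers no direct guidance here. Given the small size of the change, compound 4 is expected to show a 1.0-fold lower number from compound 3 to compound 4 (0.01 log units; within the scatter), that is, no step beyond the scatter in this assay. The estimate for compound 4 is therefore 13 ug/mL, with a range from 7 ug/mL to 25 ug/mL.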

Compound 4, half-maximal cytotoxic concentration: 53.7 ug/mL
Compound 4: the middle estimate sits 4.1-fold (0.62 log units) below what was measured; the whole stated range lies below it.
By their numbers in this assay, from the lowest: compound 2; then compounds 3 and 1 (each within the scatter of the next); then compound 4.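

Chloro in place of bromo, read as 6-bromo-1,3-benzothiazol-2-yl to 6-chloro-1,3-benzothiazol-2-yl, gives a 4.1-fold higher number from compound 3 to compound 4 (0.61 log units; beyond the scatter) in this assay on an otherwise unchanged structure. So exchanging one halogen for another at this aromatic carbon is enough to move the number beyond the scatter, which the earlier methyl-for-fluoro step, on a different pair of compounds, could not show. No measurement shown here accounts for this shift.

Where an amine or a methoxy group at this carbon would fall in this assay stays open. So does whether the same halogen exchange would give a similar step on another core.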